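Methoxy in place of methyl on compound 2

The source may hold more compounds than are shown below. What is called first, only, known or untested is meant among the compounds shown, and "the series" means these compounds.

Measured in a functional assay on HCC 2998 cells (Homo sapiens) for antiproliferative activity; a higher number here means a weaker inhibitor of growth, a lower number a stronger inhibitor of growth:
- compound 1 `Cc1cc(-c2nc3ccccc3s2)ccc1N`: > 100000 nM (a limit, not a number)
- compound 2 `COc1ccc(-c2nc3cc(F)ccc3s2)cc1C`: 540 nM
- compound 3 `Oc1ccc(-c2nc3cc(F)ccc3s2)cc1O`: 1640 nM

Among the measured compounds shown here, only two of the three compounds have a number, since compound 1 is known by a limit alone. Of these two, compound 2 holds the lower number, at 540 nM. Compound 3 stands higher at 1640 nM, a gap beyond the scatter. Compound 2 is therefore the natural reference for the next comparison.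

Compound 4 `COc1ccc(-c2nc3cc(F)ccc3s2)cc1OC` has not yet been measured. It departs from compound 2 by one change: methoxy in place of methyl on an aromatic carbon. This is methoxy in place of methyl on an aromatic carbon, ortho to a methoxy group and meta to a large group.

For the measured compounds named here, no measured pair in this small set shows this change, so the expectation in this assay is a judgement with a wide margin. Starting from compound 2 at 540 nM, a lower number is expected, by a large step well beyond the scatter. The expected change is a 22-fold lower number from compound 2 to compound 4 (1.33 log units; beyond the scatter). For compound 4 the estimated value is 25 nM, with an expected range from 2 nM to 400 nM.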

Compound 4, concentration for 50% growth inhibition: 0.25 nM
Beside the measured number, compound 4's estimate is 100-fold (2.00 log units) above it; measured number below the stated range.
By their numbers in this assay, from the lowest: compound 4; then compound 2; then compound 3. At a limit, above all of these: compound 1.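

In this assay, the aromatic carbon ortho to a methoxy group and meta to a large group proves highly sensitive to what it carries: methoxy in place of methyl gives a 2200-fold lower number from compound 2 to compound 4 (3.33 log units; beyond the scatter), a large step beyond the scatter. Among the compounds shown here, this is the first step that can be read across a single change, and it shows that one substituent at this carbon can shift growth inhibition by far more than the earlier values could reveal. Nothing available accounts for the size of this step.

Still open, from the compounds shown here alone, is whether the gain belongs to methoxy itself or would extend to other groups at this carbon, such as ethoxy, a longer alkoxy chain, an amine or a chlorine. For the compounds shown here, also open is whether the same change would carry over with a different substituent on the fluorinated part of the core, since compound 2 and compound 4 share that part and only this one pair speaks for the change.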